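The source may report more compounds than this note shows. Statements on the series, on what has been measured and on what is new or still open speak of the compounds shown alone.

In an assay on cells with melanin-concentrating hormone receptor 1 (Homo sapiens) as the target, read by radioligand binding (on this read-out higher numbers stand for weaker inhibition and lower numbers for stronger inhibition), compound 3 `CC1CCC(Oc2cccc3ccc(N)nc23)C1` gives 823 nM. Among the measured compounds shown here, this is the only actual number among the three measured compounds; the other two values are limits of the assay. Compound 1 `Nc1ccc2cccc(OCC3CC3)c2n1` reaches only the limit > 2000 nM. Compound 2 `CC(C)=CCOc1cccc2ccc(N)nc12` likewise stops at the limit > 2000 nM. Both carry a smaller or open group on the oxygen where compound 3 has a 3-methylcyclopentyl, and the steps of an at least 2.4-fold lower number from compound 1 to compound 3 (0.38 log units; beyond the scatter) and an at least 2.4-fold lower number from compound 2 to compound 3 (0.38 log units; beyond the scatter) can be read only as lower bounds, since the limit of > 2000 nM in this assay, at which 2 of the 3 values shown sit, caps what the assay reports.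

Compound 4 `CC(C)(C)CCOc1cccc2ccc(N)nc12` has not been measured. It differs from compound 3 by 3,3-dimethylbutyl in place of 3-methylcyclopentyl on an oxygen on an aromatic ring. This change removes the five-membered ring of compound 3 and puts a branched open chain in its place, running in the opposite sense to both measured steps, each of which moved from a chain or a small ring toward the five-membered ring and lowered the number beyond the scatter. The step of a 1.9-fold higher number from compound 3 to compound 4 (0.29 log units; within the scatter) is therefore expected to raise the number for compound 4, possibly back to the limit. The estimate for compound 4 is 1600 nM, with a range from 500 nM to 4000 nM, and a real chance that only a limit is returned.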

Compound 4, half-maximal inhibitory concentration: 201 nM
For compound 4 the middle estimate is 8.0-fold (0.90 log units) above the measured one, and the stated range ends above it.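

At this place, on an oxygen on an aromatic ring, a ring turns out not to be needed: in this assay, replacing 3-methylcyclopentyl with the open 3,3-dimethylbutyl chain gives a 4.1-fold lower number from compound 3 to compound 4 (0.61 log units; beyond the scatter). Among the compounds shown here, both groups hold 6 heavy atoms, all carbon, so this step separates the shape of the group from its size in a way the earlier compounds could not, and it shows that moving from a ring to an open chain can lower the number. Open chains do not all do so, as compound 2 also has one and stops at a limit, and the comparisons with the two weaker compounds, an at least 9.9-fold lower number from compound 2 to compound 4 (0.99 log units; beyond the scatter) and an at least 9.9-fold lower number from compound 1 to compound 4 (0.99 log units; beyond the scatter), give only minimum sizes because of this cap: the limit of > 2000 nM in this assay, at which 2 of the 4 values shown sit.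

The compounds shown leave open whether it is the branched end of the chain that matters, which a straight hexyl chain of the same count of carbons would help to test. They also leave open whether a longer chain, or a chain ending in an amine or a carboxylic acid, would be tolerated at this oxygen.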